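Side-chain exchange on the amine nitrogen of the shared core

A few compounds are considered here, and "the series" means these few. Any claim that something is new, unique, unknown or untested is made for them only; others in the source may bear on it.

Compound 1 `CCOC(=O)C1=C(N/N=C(/Br)c2ccccc2)Nc2[nH]nc(C)c2C1c1ccc(N(C)C)cc1` — in a functional assay on HeLa cells (Homo sapiens) for inhibition, read by MTT assay, with a stated time of 48 h (a lower number here means a stronger inhibitor, a higher number a weaker inhibitor), compound 1 gives 75700 nM.
Compound 2 `CCOC(=O)C1=C(N/C=N/c2nnc(S(N)(=O)=O)s2)Nc2[nH]nc(C)c2C1c1ccc(N(C)C)cc1` — in this assay compound 2 gives 26300 nM.
Compound 3 `CCOC(=O)C1=C(N/C=N/c2cccnc2Cl)Nc2[nH]nc(C)c2C1c1ccc(N(C)C)cc1` — in this assay compound 3 gives 4630 nM.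

Compound 2 holds the second highest of the three numbers. Its nearest neighbour is reached by a 2.9-fold lower number from compound 1 to compound 2 (0.46 log units; beyond the scatter) and its furthest by a 5.7-fold lower number from compound 2 to compound 3 (0.75 log units; beyond the scatter); both steps lie beyond the scatter, so compound 2 sits clearly between the other two.

Compound 4 `CCOC(=O)C1=C(N/N=C(/Cl)C#N)Nc2[nH]nc(C)c2C1c1ccc(N(C)C)cc1` differs from compound 2 in one place: a group of 5 heavy atoms (2 carbon, 2 nitrogen, 1 chlorine; no ring) in place of a group of 11 heavy atoms (3 carbon, 4 nitrogen, 2 oxygen, 2 sulfur; one five-membered aromatic ring with 3 hetero atoms), on an amine nitrogen. All three measured steps exchange the group on this same amine nitrogen, so all bear on the question. The largest is a 16-fold lower number from compound 1 to compound 3 (1.21 log units; beyond the scatter); the others are modest. In every measured case, however, a ring is replaced by a ring. Among the compounds with values here, the entering group of compound 4 has no ring and carries a triple bond, so no measured step covers this kind of change directly. The highest number in the set belongs to compound 1, whose side chain, like that of compound 4, carries a double bond outside aromatic rings. On this basis compound 4 is expected to land between compound 2 and compound 1, a modest rise in number that may not exceed the scatter. The estimate for compound 4 is 45000 nM, with a range of 12000 nM to 170000 nM. This corresponds to an expected step of a 1.7-fold higher number from compound 2 to compound 4 (0.23 log units; within the scatter).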

Compound 4, half-maximal inhibitory concentration: 26200 nM
Beside the measured number, compound 4's estimate is 1.7-fold (0.23 log units) above it; the measured number falls inside the stated range.
By their numbers in this assay, from the lowest: compound 3; then compounds 4 and 2 (each within the scatter of the next); then compound 1.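

Working notes on the amine nitrogen of the shared core: in this assay, the measured side chains no longer all carry a ring, and the ring-free group with a nitrile gives a number within the scatter of the group carrying 5-sulfamoyl-1,3,4-thiadiazol-2-yl (a 1.0-fold lower number from compound 2 to compound 4 (0.00 log units; within the scatter)). A ring in this side chain is thus not needed to reach the level of compound 2, even though the entering group is much smaller by heavy-atom count and has fewer hydrogen-bond donors and acceptors. The ring-free group also stands apart from both ends of the set (a 2.9-fold lower number from compound 1 to compound 4 (0.46 log units; beyond the scatter); a 5.7-fold higher number from compound 3 to compound 4 (0.75 log units; beyond the scatter)), so the absence of a ring does not by itself match the highest or the lowest number, and no measurement shown here explains these positions.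

With a single ring-free side chain, the separate contributions of its nitrile and its chlorine remain unresolved. A carboxylic acid, a primary amine or a longer alkyl chain on this amine nitrogen would show whether the level of compound 2 and compound 4 extends to other ring-free groups.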